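Removing the Methoxy Group from Compound 1

The source may report more compounds than this note shows. Statements on the series, on what has been measured and on what is new or still open speak of the compounds shown alone.

Compound 1 `COc1ccc(CNc2nc([Se]C)nc3ccccc23)cc1`: in a functional assay on CCRF-CEM cells (Homo sapiens) for cytotoxicity, read by MTT assay, with a stated time of 72 h (on this read-out higher numbers stand for weaker inhibition of growth and lower numbers for stronger inhibition of growth), compound 1 gives > 100000 nM, which is a limit of the assay and not a number.
Compound 2 `COc1ccc(CNc2nc([SeH])nc3ccccc23)cc1`: in this assay compound 2 gives > 100000 nM, again a limit.
Compound 3 `CSc1nc(NCCCCc2ccccc2)c2ccccc2n1`: in this assay compound 3 gives > 100000 nM, also a limit.

Compound 1 therefore stands at the limit, as do both other measured compounds, all three sitting at the limit of > 100000 nM in this assay, at which 3 of the 3 values shown sit. Among the compounds with values here, the one measured step, a step that the two limits leave unreadable from compound 1 to compound 2, has no readable size, both of its ends being limits. Compound 4 `C[Se]c1nc(NCc2ccccc2)c2ccccc2n1` differs from compound 1 by hydrogen in place of methoxy on an aromatic carbon. Within the data shown here, no measured step bears on this change, and nothing among the measured values points to a move away from the limit. Compound 4 is therefore expected to give 100000 nM in this assay, within 30000 nM to 300000 nM, and most probably to be reported again only as a limit. The estimated step of a number no higher from compound 1 to compound 4 (the limit leaves the size open) is accordingly expected to be none beyond the scatter.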

Compound 4, concentration for total growth inhibition: 61600 nM
Compound 4: middle estimate off by 1.6-fold (0.21 log units), on the high side; low and high end bracket the measured number.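

In this assay, compound 4 is the only compound shown that gives a number rather than a limit, so hydrogen in place of methoxy on an aromatic carbon is the first change here to move a compound off that limit. The change gives an at least 1.6-fold lower number from compound 1 to compound 4 (0.21 log units; that floor lies within the scatter), and the true size of the step stays open because the value of compound 1 is only a limit: the limit of > 100000 nM in this assay, at which 3 of the 4 values shown sit.

As far as these compounds go, it remains open whether another group at this place, such as a hydroxyl, a chlorine or an amine, would lower the number further. Also open, from the compounds shown here alone, is whether removing the methoxy group would act in the same way with hydrogen in place of methyl on the selenium, as in compound 2.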